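The source may hold more compounds than are shown below. What is called first, only, known or untested is meant among the compounds shown, and "the series" means these compounds.

Measured compounds:
compound 1 `CC(=O)OC(C)n1cnc2c(Cl)nc(N)nc21` — > 500000 nM
compound 2 `COc1nc(I)nc2c1ncn2OCCO` — > 500000 nM

Of the compounds shown here, two have been tested in a functional assay (Homo sapiens) for inhibition; a higher number here means a weaker inhibitor, a lower number a stronger inhibitor. Compound 1 `CC(=O)OC(C)n1cnc2c(Cl)nc(N)nc21` reaches only > 500000 nM, which is a limit of the assay and not a number. Compound 2 `COc1nc(I)nc2c1ncn2OCCO` likewise stops at > 500000 nM, again a limit rather than a measured value. Compound 1 therefore stands at the limit of > 500000 nM in this assay, at which 2 of the 2 values shown sit, and nothing in the measured values sets it apart from compound 2. Going by the values given here, no pair of measured compounds that differ in one place is available, so no measured step exists.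

Compound 3 `CC(=O)OC(C)n1cnc2c(Cl)nc(F)nc21`, not yet tested in this assay, is related to compound 1 by fluoro in place of amino on an aromatic carbon, in words: fluoro in place of amino on an aromatic carbon. The change sits on an aromatic carbon of a six-membered aromatic ring with two nitrogen, between two ring nitrogen atoms, meta to a chloro group and meta and para to a fused ring. Among the compounds with values here, with compound 1 itself at a limit, no measured step shows which way this change pulls. The expected step is a number no higher from compound 1 to compound 3 (the limit leaves the size open), nothing beyond the scatter. Compound 3 is estimated at 500000 nM, within 100000 nM to 2000000 nM.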

Compound 3, half-maximal inhibitory concentration: 93300 nM
Beside the measured number, compound 3's estimate is 5.4-fold (0.73 log units) above it; the whole stated range lies above it.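

In this assay, going by these compounds alone, the replacement of amino by fluoro on this aromatic carbon, between two ring nitrogen atoms, gives the first step that can be read: an at least 5.3-fold lower number from compound 1 to compound 3 (0.72 log units; beyond the scatter). Within the data shown here, this shows that the group at this position can move the result on the shared core, and that fluoro here brings a measured number where amino does not, which the earlier compounds could not show: the limit of > 500000 nM in this assay, at which 2 of the 3 values shown sit. The size of the step remains a lower bound, as compound 1 gives > 500000 nM, which is a limit of the assay and not a number.

Among these compounds, the single pair cannot tell whether the step comes from the loss of amino or the arrival of fluoro, nor whether the hydrogen-bond donor and acceptor that leave with amino play any part in it. From the compounds shown here alone, how a methyl group, a hydroxyl group or a dimethylamino group would read at this position stays open, as does whether any group here would give a much lower number than compound 3 does.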